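Formyl in place of dimethylcarbamoyl: notes on the series

A few compounds are considered here, and "the series" means these few. Any claim that something is new, unique, unknown or untested is made for them only; others in the source may bear on it.

Measured in a functional assay (Homo sapiens); a lower number here means a stronger inhibitor, a higher number a weaker inhibitor:
- compound 1 `Nc1nc2ccnc(-c3cccc(C(F)(F)F)c3)n2n1`: 2200 nM; 2200 nM (2 entries) (two entries, same value)
- compound 2 `CN(C)C(=O)c1cccc(-c2nccc3nc(N)nn23)c1`: 3500 nM

For the measured compounds named here, compound 2, at 3500 nM, is the only other measured compound, and its value lies within the usual scatter of compound 1 at 2200 nM; 2200 nM (2 entries). Going by the values given here, no step between measured compounds that differ in one place is available, so the series offers no direct measure of a single change.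

The next compound is compound 3 `Nc1nc2ccnc(-c3cccc(C=O)c3)n2n1`, still unmeasured. Going from compound 2 to compound 3 puts hydrogen in place of dimethylamino on a carbonyl carbon, which reads as dimethylcarbamoyl to formyl: hydrogen in place of dimethylamino on a carbonyl carbon.

With compound 1 at 2200 nM; 2200 nM (2 entries) and compound 2 at 3500 nM, the two values give no sign of a large swing. The step expected in this assay is a 1.3-fold lower number from compound 2 to compound 3 (0.10 log units; within the scatter), which is not expected to exceed the usual scatter. For compound 3 the estimated value is 2800 nM, with an expected range of 900 nM to 9000 nM.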

Compound 3, half-maximal inhibitory concentration: 700 nM
Compound 3: middle estimate off by 4.0-fold (0.60 log units), on the high side; the whole stated range lies above it.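

In this assay, replacing dimethylamino with hydrogen on a carbonyl carbon gives the first direct measure of a single change in the series (a 5.0-fold lower number from compound 2 to compound 3 (0.70 log units; beyond the scatter)), and that step lies beyond the scatter. The values of compounds 1 and 2 alone gave no sign of this: they showed no large swing, whereas the step from dimethylcarbamoyl to formyl shows that the read-out responds to what sits on this carbonyl carbon. No measurement available here accounts for the step.

A single pair cannot show whether the gain follows from the loss of dimethylamino or from the presence of the formyl group itself. Also open, on these data alone, is how a primary amide, a carboxylic acid or a hydroxymethyl group would read in this assay at this place.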